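Sulfonyl substituent exchange on the acylsulfonamide series

A few compounds are considered here, and "the series" means these few. Any claim that something is new, unique, unknown or untested is made for them only; others in the source may bear on it.

Compound 3 `O=C(NS(=O)(=O)CCNCc1ccccc1)c1ccc(Nc2nc(NC3(c4ccc(Cl)cc4)CC3)nc(OCC(F)(F)F)n2)cc1` carries a 2-(benzylamino)ethyl group on the sulfonyl sulfur. Going by the values given here, in an ADME assay on microsomes from liver (Homo sapiens) for metabolic stability, with a stated time of 10 min (on this read-out lower numbers stand for a less stable compound and higher numbers for a more stable compound), compound 3 gives 99%, the lowest of the three numbers so far, though within the scatter of both others. Compound 1 `CC(C)S(=O)(=O)NC(=O)c1ccc(Nc2nc(NC3(c4ccc(Cl)cc4)CC3)nc(OCC(F)(F)F)n2)cc1`, with isopropyl on the sulfonyl sulfur, gives 100% in this assay; compound 2 `O=C(NS(=O)(=O)c1ccccc1)c1ccc(Nc2nc(NC3(c4ccc(Cl)cc4)CC3)nc(OCC(F)(F)F)n2)cc1`, with phenyl there, gives 100%. The steps among them are no change at the digits printed from compound 1 to compound 2 (within the scatter), a number 1 percentage points lower from compound 1 to compound 3 (within the scatter) and a number 1 percentage points lower from compound 2 to compound 3 (within the scatter), each within the scatter.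

Compound 4 `Cc1ccccc1S(=O)(=O)NC(=O)c1ccc(Nc2nc(NC3(c4ccc(Cl)cc4)CC3)nc(OCC(F)(F)F)n2)cc1` differs from compound 3 as follows: 2-methylphenyl in place of 2-(benzylamino)ethyl on a sulfonyl sulfur. All three measured steps bear on this, since each exchanges the group on the sulfonyl sulfur, and none moved this assay beyond the scatter. A 2-methylphenyl group is a further exchange at the same place, so no step beyond the scatter is expected in this assay, that is an expected step of no change at the digits printed from compound 3 to compound 4 (within the scatter). Compound 4 is therefore expected to give 99%, with a range from 90% to 100%.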

Compound 4, percent of the compound remaining: 100%
Beside the measured number, compound 4's estimate is 1 percentage points below it; the measured number falls inside the stated range.
By their numbers in this assay, from the lowest: compounds 3, 1, 2 and 4 (each within the scatter of the next).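

Methyl in place of hydrogen on an aromatic carbon, the first substitution on an aromatic group at this place, leaves the read-out in this assay flat (no change at the digits printed from compound 2 to compound 4 (within the scatter)). The same holds when 2-methylphenyl enters in place of the larger, nitrogen-bearing 2-(benzylamino)ethyl (a number 1 percentage points higher from compound 3 to compound 4 (within the scatter)) or in place of the non-aromatic isopropyl (no change at the digits printed from compound 1 to compound 4 (within the scatter)), so across these four compounds this place on the sulfonyl sulfur tolerates alkyl, aminoalkyl, phenyl and methyl-substituted phenyl groups without a step beyond the scatter. Nothing available explains this flat read-out.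

Going by these compounds, whether a carboxylic acid, a primary amine or a longer alkyl chain on the sulfonyl sulfur would give a step beyond the scatter remains open. The four compounds also leave open how this assay responds to changes elsewhere on the shared core.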